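Methoxy for chloro on the bromo member

This account rests on a few compounds, and the source may have more. Where it says the series, first, only, none or still open, it means among the compounds named here.

In a functional assay on MCF7 cells (Homo sapiens) for antiproliferative activity, read by MTT assay, with a stated time of 48 h (a lower number here means a stronger inhibitor, a higher number a weaker inhibitor), compound 1 (`Clc1ccc(-c2nn(-c3ccccc3)cc2-c2nc3cc(Cl)ccc3[nH]2)cc1`) stands at 1170 nM and compound 3 (`COc1ccc2[nH]c(-c3cn(-c4ccccc4)nc3-c3ccc(Cl)cc3)nc2c1`) at 1760 nM while compound 2 (`Clc1ccc(-c2nn(-c3ccccc3)cc2-c2nc3cc(Br)ccc3[nH]2)cc1`) stands at 1920 nM with no gap among the three beyond the scatter. Compound 4 (`COc1ccc(-c2nn(-c3ccccc3)cc2-c2nc3cc(Br)ccc3[nH]2)cc1`) differs from compound 2 by methoxy in place of chloro on an aromatic carbon so that 4-chlorophenyl becomes 4-methoxyphenyl. Within the data shown here, no step at this carbon has been measured. The closest evidence comes from another carbon of the shared core: a 1.5-fold higher number from compound 1 to compound 3 (0.18 log units; within the scatter) for methoxy in place of chloro and a 1.1-fold lower number from compound 2 to compound 3 (0.04 log units; within the scatter) for methoxy in place of bromo. Neither exceeds the scatter, so no clear direction is expected. The estimated change is a 1.1-fold lower number from compound 2 to compound 4 (0.03 log units; within the scatter) and is expected to stay within the scatter. The estimate for compound 4 is 1800 nM with an expected range of 800 nM to 4000 nM in this assay at this stage.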

Compound 4, half-maximal inhibitory concentration: 1830 nM
Estimate against measurement, compound 4: 1.0-fold (0.01 log units) below; the measured number falls inside the stated range.
By their numbers in this assay, from the lowest: compounds 1, 3, 4 and 2 (each within the scatter of the next).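

Methoxy in place of chloro on the 4-chlorophenyl ring gives a 1.0-fold lower number from compound 2 to compound 4 (0.02 log units; within the scatter) in this assay, the first reading at this carbon among the compounds shown. The exchange therefore stays within the scatter at both carbons where it can be read, and the two steps do not separate beyond the scatter: the same change on two cores in this assay, a 1.5-fold higher number (0.18 log units; within the scatter) from compound 1 to compound 3 and a 1.0-fold lower number (0.02 log units; within the scatter) from compound 2 to compound 4, 1.6-fold (0.20 log units) apart, within the scatter of two such steps

Only chloro and methoxy are shown at this carbon. On these data alone, whether an amine or a carboxylic acid there would move the number beyond the scatter remains open.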